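Aminopyridine nitriles: hydroxycyclohexyl against methoxycyclohexylmethyl

This account rests on a few compounds, and the source may have more. Where it says the series, first, only, none or still open, it means among the compounds named here.

Measured so far:
compound 1, `N#Cc1cnc(NCc2cnccc2C(F)(F)F)cc1N[C@H]1CC[C@H](O)CC1`: 350 nM
compound 2, `N#Cc1cnc(NCc2ccccc2C(F)(F)F)cc1N[C@H]1CC[C@H](O)CC1`: 4000 nM

In an assay on isolated protein for inhibition of protein kinase C theta type (Homo sapiens), read by TR-FRET, with a stated time of 2 h (a higher number here means a weaker inhibitor, a lower number a stronger inhibitor), compound 1 gives 350 nM, the lower of the two numbers in hand. Compound 2 gives 4000 nM in this assay, and the gap between compound 1 and compound 2 lies beyond the scatter.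

Compound 3, `CO[C@H]1CC[C@H](CNc2cc(NCc3cnccc3C(F)(F)F)ncc2C#N)CC1`, is not yet measured. It differs from compound 1 by (4-methoxycyclohexyl)methyl in place of 4-hydroxycyclohexyl on a nitrogen on an aromatic ring. Among the compounds with values here, no measured pair shows this change, so the size of the step rests on judgment alone: the hydrogen-bond donor of the leaving group is gone and the ring sits one bond further from the nitrogen. A step towards a higher number, beyond the scatter, is expected, a 2.9-fold higher number from compound 1 to compound 3 (0.46 log units; beyond the scatter). Compound 3 is accordingly estimated at 1000 nM, with a range from 300 nM to 4000 nM.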

Compound 3, half-maximal inhibitory concentration: 330 nM
Estimate against measurement, compound 3: 3.0-fold (0.48 log units) above; the range from low to high includes it.
By their numbers in this assay, from the lowest: compounds 3 and 1 (each within the scatter of the next); then compound 2.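

In this assay the exchange of 4-hydroxycyclohexyl for (4-methoxycyclohexyl)methyl on a nitrogen on an aromatic ring gives a 1.1-fold lower number from compound 1 to compound 3 (0.03 log units; within the scatter) and so leaves the reading unchanged within the scatter. This position therefore tolerates a group with no hydrogen-bond donor and with the ring one bond further from the nitrogen, at least on the core of compound 1. Compounds 1 and 2 both carry 4-hydroxycyclohexyl and showed nothing about this position.

The change alters the oxygen substituent and the link to the ring at once, so 4-methoxycyclohexyl and (4-hydroxycyclohexyl)methyl would be needed to read each part alone. Also open, from the compounds shown here alone, is whether an amine or a carboxylic acid at the end of the ring, or a longer chain to it, fits here equally well.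

No evidence accompanies this result to account for the two groups reading alike.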